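Adding fluoro to the 3-chlorophenyl amide

The compounds below may be only part of what the source reports. "The series", "measured", "known", "first", "only" and "open" are said of these compounds alone.

Measured in an in vitro ADME assay on microsomes from liver (Homo sapiens) for pharmacokinetics, read by LC-MS, with a stated time of 10 min, tested at 1 uM; a higher number here means faster removal of the compound, a lower number slower removal:
- compound 1 `CN1C[C@H](C(=O)Nc2ccccc2)[C@@H](c2ccc(/C=C/C(=O)Nc3ccccc3N)cc2)C1`: 7 mL/min/kg
- compound 2 `Cc1ccc(NC(=O)[C@H]2CN(C)C[C@@H]2c2ccc(/C=C/C(=O)Nc3ccccc3N)cc2)cc1`: 15 mL/min/kg
- compound 3 `CN1C[C@H](C(=O)Nc2cccc(Cl)c2)[C@@H](c2ccc(/C=C/C(=O)Nc3ccccc3N)cc2)C1`: 7 mL/min/kg

Compound 3 stands level with compound 1, and the two share the lowest number of the three. Compound 2 is the outlier, with a 2.1-fold lower number from compound 2 to compound 3 (0.33 log units; beyond the scatter).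

The next change leads to compound 4 `CN1C[C@H](C(=O)Nc2ccc(F)c(Cl)c2)[C@@H](c2ccc(/C=C/C(=O)Nc3ccccc3N)cc2)C1`, which differs from compound 3 by fluoro in place of hydrogen on an aromatic carbon. This is fluoro in place of hydrogen on an aromatic carbon, ortho to a chloro group and para to a large group, turning 3-chlorophenyl into 3-chloro-4-fluorophenyl.

Going by the values given here, no fluoro step has been measured, so two other steps on the same aromatic ring serve as the guide. The chloro step gave no change at the digits printed from compound 1 to compound 3 (within the scatter). Among the compounds with values here, the methyl step gave a 2.1-fold higher number from compound 1 to compound 2 (0.33 log units; beyond the scatter), and compound 2 is the only measured compound with a new group para to a large group. With only these two modest precedents, no shift beyond the scatter is expected in this assay, though a small rise remains possible. The expected step is a 1.1-fold higher number from compound 3 to compound 4 (0.06 log units; within the scatter). For compound 4 the estimated clearance is 8 mL/min/kg, with an expected range from 4 mL/min/kg to 15 mL/min/kg.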

Compound 4, clearance: 15 mL/min/kg
Compound 4: middle estimate off by 1.9-fold (0.27 log units), on the low side; the measured number falls inside the stated range.
By their numbers in this assay, from the lowest: compounds 1 and 3 (each within the scatter of the next); then compounds 2 and 4 (each within the scatter of the next).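

In this assay, the position para to a large group responds to a single fluorine atom, with a 2.1-fold higher number from compound 3 to compound 4 (0.33 log units; beyond the scatter), whereas the chloro step on the same ring, no change at the digits printed from compound 1 to compound 3 (within the scatter), left the number in place. Across the four compounds, the two with a new group para to a large group, methyl in compound 2 and fluoro in compound 4, share the higher level, with none going against this: no change at the digits printed from compound 2 to compound 4 (within the scatter), and the full change from the unsubstituted phenyl amide gives a 2.1-fold higher number from compound 1 to compound 4 (0.33 log units; beyond the scatter). Nothing measured here gives a reason for the fluoro step.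

On these data alone, compound 4 carries both halogens, so it remains open whether fluoro would give the same step on the phenyl amide of compound 1, without the chloro group ortho to it. As far as these compounds go, it is also open whether the level shared by compound 2 and compound 4 extends to other groups at this position, such as methoxy, an amine or a carboxylic acid, or whether those would instead stay level with compound 1 and compound 3.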